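A few compounds are considered here, and "the series" means these few. Any claim that something is new, unique, unknown or untested is made for them only; others in the source may bear on it.

Working notes, values in a functional assay on HCT-116 cells (Homo sapiens) for cytotoxicity, read by MTT assay; on this read-out higher numbers stand for weaker inhibition and lower numbers for stronger inhibition:

- compound 1 `Cc1cc(O)c(C(=O)/C=C/c2ccccc2F)c(=O)o1`: > 100000 nM (a limit)
- compound 2 `Cc1cc(O)c(C(=O)/C=C/c2ccc(F)cc2F)c(=O)o1`: 80300 nM
- compound 3 `CCOc1ccc(/C=C/C(=O)c2c(O)cc(C)oc2=O)cc1`: > 100000 nM (a limit)

Compound 1 stands at the limit of > 100000 nM in this assay, at which 2 of the 3 values shown sit, so it offers a limit and not a number to start from. The change to compound 4 `Cc1cc(O)c(C(=O)/C=C/c2ccccc2Cl)c(=O)o1` is chloro in place of fluoro on an aromatic carbon, ortho to a large group. Going by the values given here, the one measured step that bears on it is an at least 1.2-fold lower number from compound 1 to compound 2 (0.09 log units; that floor lies within the scatter), and that is a different exchange, fluoro in place of hydrogen on an aromatic carbon. It gives only weak guidance, so no step beyond the scatter is expected in this assay, and no direction can be argued with confidence. Compound 4 may well report only as a limit too.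

The estimated step is an at least 1.1-fold lower number from compound 1 to compound 4 (0.04 log units; that floor lies within the scatter) and is expected to stay small.

For compound 4 the expected value is 90000 nM, with an estimated range from 40000 nM to 150000 nM.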

Compound 4, half-maximal inhibitory concentration: > 100000 nM
Compound 4 gave a limit, no number; the forecaster's own chance of this, stated with the estimate: 60%; middle value at least 1.1-fold (0.04 log units) from the limit.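

No step can be read between compound 1 and compound 4, since both report only as limits in this assay: the limit of > 100000 nM in this assay, at which 3 of the 4 values shown sit.

The compounds shown leave open whether chloro in place of fluoro changes the read-out at all, and what actual number either compound would carry.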